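Swapping the chain amine on a Toll-like receptor 9 antagonist

The source may hold more compounds than are shown below. What is called first, only, known or untested is meant among the compounds shown, and "the series" means these compounds.

Compound 2 `CCN1CCN(c2nc(NCc3ccc(F)cc3)nc3c2ncn3CCCN2CCCC2)CC1` holds the lowest of the two numbers recorded in an assay on HEK293 cells for antagonist activity at Toll-like receptor 9 (Homo sapiens), read by spectrophotometry; a lower number here means a stronger inhibitor, a higher number a weaker inhibitor: compound 2 gives 40 nM, whereas compound 1 `CCN1CCN(CCCn2cnc3c(N4CCN(CC)CC4)nc(N4CCCC4)nc32)CC1` gives 500 nM in this assay, a gap beyond the scatter. Compound 3 `CCN1CCN(CCCn2cnc3c(N4CCN(CC)CC4)nc(NCc4ccc(F)cc4)nc32)CC1` has not been measured. It differs from compound 2 in one place: 4-ethylpiperazin-1-yl in place of pyrrolidin-1-yl on a saturated chain carbon, three bonds along the chain from an aromatic nitrogen. Among the compounds with values here, with no measured pair showing this exchange alone, the step is expected to be small, at most a modest loss, as a 2.0-fold higher number from compound 2 to compound 3 (0.30 log units; within the scatter). Compound 3 is therefore estimated at 80 nM in this assay, within a range from 25 nM to 250 nM.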

Compound 3, half-maximal inhibitory concentration: 470 nM
Compound 3: the middle estimate sits 5.9-fold (0.77 log units) below what was measured; the whole stated range lies below it.
By their numbers in this assay, from the lowest: compound 2; then compounds 3 and 1 (each within the scatter of the next).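

At this position the chain amine matters: in this assay the exchange on the saturated chain carbon gives a 12-fold higher number from compound 2 to compound 3 (1.07 log units; beyond the scatter). With 4-ethylpiperazin-1-yl on the chain, (4-fluorobenzyl)amino in place of pyrrolidin-1-yl on an aromatic carbon gives only a 1.1-fold lower number from compound 1 to compound 3 (0.03 log units; within the scatter), so the low number of compound 2 depends on the pyrrolidin-1-yl at the chain end and not on (4-fluorobenzyl)amino alone. Nothing available explains this step. As far as these compounds go, whether a piperidine, a morpholine or a dimethylamino group at the chain end, or a shorter chain, would keep the number of compound 2 remains open.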